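Aryl replacement on the shared core: compound 1 to compound 4

The compounds below may be only part of what the source reports. "The series", "measured", "known", "first", "only" and "open" are said of these compounds alone.

Measured so far in a functional assay on PC-3 cells (Homo sapiens) for inhibition; a lower number here means a stronger inhibitor, a higher number a weaker inhibitor:
- compound 1, `Cc1c(C(=O)N/N=C\c2ccccn2)oc2cccc(O)c12`: >= 40000 nM
- compound 2, `Cc1c(C(=O)N/N=C\c2ccc(O)c(O)c2O)oc2cccc(O)c12`: >= 40000 nM
- compound 3, `Cc1c(C(=O)N/N=C\c2ccc(C(F)(F)F)cc2)oc2cccc(O)c12`: >= 40000 nM

Compound 1 reports only a limit of this assay, not a number. Compound 2 likewise reports only a limit. Compound 3 also sits at a limit. For the measured compounds named here, compound 1 therefore stands nowhere apart from the other two: the limit of >= 40000 nM in this assay, at which 3 of the 3 values shown sit, and no step between measured compounds can be read from these values.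

Compound 4, `Cc1c(C(=O)N/N=C\c2cccc(O)c2)oc2cccc(O)c12`, is not yet measured. Relative to compound 1 the change is 3-hydroxyphenyl in place of pyridin-2-yl on a carbon with a double bond to nitrogen. Compound 2 already carries a carbon-only six-membered ring with hydroxy substitution in place of the pyridin-2-yl and stays at the limit. Compound 3 carries a carbon-only ring with trifluoromethyl and stays at the limit. On this basis the step of a number no higher from compound 1 to compound 4 (the limit leaves the size open) is expected to be none beyond the scatter, with compound 4 most likely reported again as a limit rather than a number. Compound 4 is estimated at 40000 nM, with a range from 15000 nM to 100000 nM.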

Compound 4, half-maximal inhibitory concentration: 17600 nM
Estimate against measurement, compound 4: 2.3-fold (0.36 log units) above; low and high end bracket the measured number.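

In this assay, the aryl group on the carbon with a double bond to nitrogen can yield a number rather than a limit: 3-hydroxyphenyl in place of pyridin-2-yl gives an at least 2.2-fold lower number from compound 1 to compound 4 (0.35 log units; beyond the scatter). Compound 4 is the only compound shown that leaves the limit: the limit of >= 40000 nM in this assay, at which 3 of the 4 values shown sit. Compound 2 also has hydroxy substitution on a carbon-only ring, yet its >= 40000 nM is a limit, so neither that ring type nor hydroxy substitution alone is enough to give a number.

From the compounds shown here alone, the full size of the step stays open, as compound 1 has only a limit to compare against. Going by these compounds, it is also open whether a plain phenyl, or a methoxy or amine group in place of the hydroxy of 3-hydroxyphenyl, would give a number in this assay.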